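A few compounds are considered here, and "the series" means these few. Any claim that something is new, unique, unknown or untested is made for them only; others in the source may bear on it.

Compound 1 `Cc1ccc(-n2cc(COc3cccc(NC(=O)Nc4ccc(Cl)c(C(F)(F)F)c4)c3)nn2)cc1`: 5430 nM
Compound 2 `CC(C)c1ccc(-n2cc(COc3cccc(NC(=O)Nc4ccc(Cl)c(C(F)(F)F)c4)c3)nn2)cc1`: 2470 nM
Compound 3 `O=C(Nc1cccc(OCc2cn(-c3cccc(F)c3)nn2)c1)Nc1ccc(Cl)c(C(F)(F)F)c1`: 2120 nM

In a functional assay on HepG2 cells (Homo sapiens) for inhibition, read by MTT assay, with a stated time of 72 h (a higher number here means a weaker inhibitor, a lower number a stronger inhibitor), compound 3 sits at the low end of these three numbers: the step of a 2.6-fold lower number from compound 1 to compound 3 (0.41 log units; beyond the scatter) is beyond the scatter, whereas a 1.2-fold lower number from compound 2 to compound 3 (0.07 log units; within the scatter) is not. Compound 4 `O=C(Nc1cccc(OCc2cn(-c3cccc(C(F)(F)F)c3)nn2)c1)Nc1ccc(Cl)c(C(F)(F)F)c1` differs from compound 3 by trifluoromethyl in place of fluoro on an aromatic carbon. The closest guide is a 2.2-fold lower number from compound 1 to compound 2 (0.34 log units; beyond the scatter), where a bulkier group on the same ring gave a modest gain; the switch a 2.6-fold lower number from compound 1 to compound 3 (0.41 log units; beyond the scatter) was of similar size. For the measured compounds named here, no step shows this exact exchange, so the expectation is a small move, likely within the scatter or a slight lowering, a 1.2-fold lower number from compound 3 to compound 4 (0.10 log units; within the scatter). Compound 4 is therefore expected to give about 1700 nM, within 700 nM to 4200 nM.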

Compound 4, half-maximal inhibitory concentration: 1270 nM
Compound 4: the middle estimate sits 1.3-fold (0.13 log units) above what was measured; measured number inside the range.
By their numbers in this assay, from the lowest: compounds 4, 3 and 2 (each within the scatter of the next); then compound 1.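

Placing trifluoromethyl where compound 3 carries fluoro, an exchange of a single atom for a larger group on this ring, leaves this assay without a clear shift (a 1.7-fold lower number from compound 3 to compound 4 (0.22 log units; within the scatter)). For the compounds shown here, compound 4 is also not clearly separated from the 4-isopropylphenyl compound (a 1.9-fold lower number from compound 2 to compound 4 (0.29 log units; within the scatter)), yet it is the first 3-substituted compound here with a wide gap to the 4-methylphenyl compound (a 4.3-fold lower number from compound 1 to compound 4 (0.63 log units; beyond the scatter)). Nothing available explains these numbers. Going by these compounds, what an amine or a carboxylic acid on this ring would do remains open, as does the effect of a longer chain.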